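The compounds below may be only part of what the source reports. "The series", "measured", "known", "first", "only" and "open" are said of these compounds alone.

The three measured compounds and their numbers:

Compound 1, `CNC(=O)C1=CC(C)(C)Oc2ccc([N+](=O)[O-])cc21`, in a functional assay on the whole organism (muscle tissue) with Rattus norvegicus as the target (a lower number here means a smaller maximal response, a higher number a larger maximal response), gives 61%.
Compound 2, `CCNC(=O)C1=CC(C)(C)Oc2ccc([N+](=O)[O-])cc21`, in this assay gives 80.5%.
Compound 3, `CCCCNC(=O)C1=CC(C)(C)Oc2ccc([N+](=O)[O-])cc21`, in this assay gives 83.2%.

All three share one core and differ only in the group carried on the amide-type nitrogen. Compound 3 sits together with compound 2 well above compound 1: the gap a number 2.7 percentage points higher from compound 2 to compound 3 (within the scatter) is within the scatter, so the two cannot be told apart, while a number 22.2 percentage points higher from compound 1 to compound 3 (beyond the scatter) and a number 19.5 percentage points higher from compound 1 to compound 2 (beyond the scatter) are clear. Compound 4, `CC1(C)C=C(C(=O)NC2CC2)c2cc([N+](=O)[O-])ccc2O1`, has not yet been measured. It differs from compound 3 in one place: cyclopropyl in place of butyl on an amide-type nitrogen. For the measured compounds named here, no measured step swaps an open chain for a ring, so none bears on this change directly. What the measured steps do show is that methyl or propyl in place of hydrogen raises the number, while ethyl in place of hydrogen further along the chain changes little. Cyclopropyl keeps carbon on that nitrogen, so compound 4 is expected to stay near compound 3, with an estimated step of a number 3.2 percentage points lower from compound 3 to compound 4 (within the scatter), within the scatter. The estimate for compound 4 in this assay is 80%, expected to fall between 66% and 92%.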

Compound 4, intrinsic activity: the largest response reached, in percent of the reference agonist's: 78%
For compound 4 the middle estimate is 2 percentage points above the measured one; measured number inside the range.
By their numbers in this assay, from the lowest: compound 1; then compounds 4, 2 and 3 (each within the scatter of the next).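

In this assay, a ring on the amide-type nitrogen does as well as an open chain: neither the change from butyl to cyclopropyl (a number 5.2 percentage points lower from compound 3 to compound 4 (within the scatter)) nor the change from ethyl to cyclopropyl (a number 2.5 percentage points lower from compound 2 to compound 4 (within the scatter)) can be told apart from the usual scatter. The change from methyl to cyclopropyl (a number 17 percentage points higher from compound 1 to compound 4 (beyond the scatter)) is clear, so only methyl stands apart, and the set of groups that reach the higher level of response now includes a three-membered ring of carbon as well as two open chains. Nothing available here says what lies behind this shared level or behind the lower response of compound 1.

The compounds shown carry only methyl, ethyl, butyl and cyclopropyl on this nitrogen, so it remains open whether a larger ring such as cyclohexyl, an aromatic ring such as phenyl, or a branched chain such as isopropyl would hold the same level. Also open, going by these compounds, is what a chain ending in an amine or a hydroxyl group would do, and what a second carbon group on the same nitrogen, in place of the amide hydrogen, would do.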